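Esterifying the Hydroxymethyl Group of Compound 2

The source may report more compounds than this note shows. Statements on the series, on what has been measured and on what is new or still open speak of the compounds shown alone.

Two measured compounds open the account. Compound 1 `C=C/C(C)=C\CC1[C@](C)(O)CC[C@H]2C(C)(C)CCC[C@]12C` gives 25 ug/mL in a functional assay on QGY-7703 cells (Homo sapiens) for antiproliferative activity; a higher number here means a weaker inhibitor, a lower number a stronger inhibitor. Compound 2 `C=C[C@@](C)(O)CCC1C(=C)CC[C@H]2[C@](C)(CO)CCC[C@]12C` does not yield a number in this assay but only a limit of the assay, recorded as > 25 ug/mL. The evidence on this point is simply (the limit of > 25 ug/mL in this assay, at which 1 of the 2 values shown sits), so where compound 2 truly stands is not pinned down. For the measured compounds named here, no step between measured compounds that differ in one place is available, and nothing measured tells how a change at this position moves the read-out.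

Compound 3 `C=C[C@@](C)(O)CCC1C(=C)CC[C@H]2[C@](C)(COC(=O)CCC(=O)O)CCC[C@]12C` differs from compound 2 in one place: (2-carboxyethyl)carbonyl in place of hydrogen on an oxygen on a saturated carbon. Without a measured step to lean on, the author expects the change from compound 2 to compound 3 to be small, a number no higher from compound 2 to compound 3 (the limit leaves the size open), not clearly beyond the scatter. Compound 3 is therefore estimated at 25 ug/mL in this assay, with a range from 12 ug/mL to 50 ug/mL, and a real chance that only a limit is reported again.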

Compound 3, half-maximal inhibitory concentration: > 25 ug/mL
Compound 3 ended at the assay's limit (the forecaster's own chance of this, stated with the estimate: 60%); the middle value sits exactly at the limit.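

For the compounds shown here, compound 2 and compound 3 both stop at a limit of the assay, so no step from one to the other can be read: the limit of > 25 ug/mL in this assay, at which 2 of the 3 values shown sit. Where either compound truly stands, and whether (2-carboxyethyl)carbonyl in place of hydrogen moves the read-out at all, remains open.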